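From propanoyl to an unsaturated amide: expected potency shift

A few compounds are considered here, and "the series" means these few. Any claim that something is new, unique, unknown or untested is made for them only; others in the source may bear on it.

Compound 1 `CCC(=O)N(Cc1ccc(OC)c(O)c1)c1cc(OC)c(OC)c(OC)c1`: 98 nM
Compound 2 `C/C=C/C(=O)N(Cc1ccc(OC)c(Br)c1)c1cc(OC)c(OC)c(OC)c1`: 10500 nM

In a functional assay on KYSE-450 cells (Homo sapiens) for inhibition, read by MTT assay, with a stated time of 48 h (a higher number here means a weaker inhibitor, a lower number a stronger inhibitor), compound 1 gives 98 nM, the lower of the two numbers, while compound 2 gives 10500 nM, a far higher number, beyond the usual scatter. Compound 2 differs from compound 1 in more than one place, so these two values show only that one pairing is much weaker than the other. Compound 3 `COc1ccc(CN(C(=O)C=C(C)C)c2cc(OC)c(OC)c(OC)c2)cc1O` has not been measured; it differs from compound 1 by 2-methylprop-1-en-1-yl in place of ethyl on a carbonyl carbon. Within the data shown here, no single-change step between measured compounds is available, so the size of this change is uncertain. Compound 3 is expected to show a moderate loss, a 3.1-fold higher number from compound 1 to compound 3 (0.49 log units; beyond the scatter). Compound 3 is estimated to give 300 nM in this assay, within 60 nM to 3000 nM.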

Compound 3, half-maximal inhibitory concentration: 280 nM
Compound 3: middle estimate off by 1.1-fold (0.03 log units), on the high side; measured number inside the range.
By their numbers in this assay, from the lowest: compound 1; then compound 3; then compound 2.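

In this assay, among these compounds, the change from ethyl to 2-methylprop-1-en-1-yl on a carbonyl carbon gives the first single-place comparison at this position: a 2.9-fold higher number from compound 1 to compound 3 (0.46 log units; beyond the scatter) and this modest loss lies beyond the scatter. The position therefore accepts the larger group with its double bond at a limited cost. Nothing measured here accounts for the loss. The compounds shown leave open whether the double bond or the added carbons carry this step, which a saturated 2-methylpropyl group on the same carbonyl carbon could separate. As far as these compounds go, how a cyclopropyl group or an amine would read there also remains open.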